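Swapping the Amine on a Weak Cytotoxic Compound

This account rests on a few compounds, and the source may have more. Where it says the series, first, only, none or still open, it means among the compounds named here.

In a functional assay on HCT-116 cells (Homo sapiens) for cytotoxicity, read by MTT assay, with a stated time of 72 h (a higher number here means a weaker inhibitor, a lower number a stronger inhibitor), compound 1 `O=S(=O)(c1ccc(Br)cc1)c1nc2ccccc2nc1N1CCCC1` gives 37700 nM. In the same test, compound 2 `Cc1ccc(S(=O)(=O)c2nc3ccccc3nc2N2CCc3ccccc3C2)cc1` gives 39000 nM. Compound 3 `O=S(=O)(c1ccc(Br)cc1)c1nc2ccccc2nc1N1CCc2ccccc2C1` gives > 50000 nM, which is a limit of the assay and not a number. Compound 3 therefore has no exact value to start from.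

The next compound is compound 4 `O=S(=O)(c1ccc(Br)cc1)c1nc2ccccc2nc1N1CCCC(O)C1`, in which 3-hydroxypiperidin-1-yl takes the place of 1,2,3,4-tetrahydroisoquinolin-2-yl on an aromatic carbon: 3-hydroxypiperidin-1-yl in place of 1,2,3,4-tetrahydroisoquinolin-2-yl on an aromatic carbon.

Among the measured compounds shown here, two measured steps bear on this change. Exchanging the amine at this same place gave an at least 1.3-fold higher number from compound 1 to compound 3 (0.12 log units; that floor lies within the scatter), and exchanging methyl for bromo gave an at least 1.2-fold higher number from compound 2 to compound 3 (0.10 log units; that floor lies within the scatter). Both are only floors, and both lie within the scatter. No step beyond the scatter is therefore expected in this assay, in either direction. The expected change is an at least 1.2-fold lower number from compound 3 to compound 4 (0.09 log units; that floor lies within the scatter). The estimated value for compound 4 is 40000 nM, with an expected range from 18000 nM to 70000 nM.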

Compound 4, half-maximal inhibitory concentration: 2110 nM
Compound 4: middle estimate off by 19-fold (1.28 log units), on the high side; the measured number lies below the stated range.
By their numbers in this assay, from the lowest: compound 4; then compounds 1 and 2 (each within the scatter of the next). At a limit, above all of these: compound 3.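

Until now, no exchange of the amine on the shared core had moved the number beyond the scatter, and compound 4 shows that this position can matter in this assay. Placing 3-hydroxypiperidin-1-yl here gives an at least 23-fold lower number from compound 3 to compound 4 (1.37 log units; beyond the scatter) and an 18-fold lower number from compound 1 to compound 4 (1.25 log units; beyond the scatter), so the change is large against both of these amines. Compound 3 stands at a limit of the assay, so the first of these steps is only a floor: the limit of > 50000 nM in this assay, at which 1 of the 4 values shown sits.

The compounds shown do not separate the hydroxyl group from the six-membered ring that carries it, so plain piperidin-1-yl or 3-methoxypiperidin-1-yl at this place would be informative. Also open, from the compounds shown here alone, is whether the step holds when methyl replaces bromo on the aromatic ring of the sulfonyl group.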